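Hydrogen in Place of Methyl: Expecting Compound 4

The compounds below may be only part of what the source reports. "The series", "measured", "known", "first", "only" and "open" are said of these compounds alone.

Compound 1, `Cc1ccc2[nH]c(=O)c(/C=N/c3ccccc3O)cc2c1`: 1350000 nM
Compound 2, `Cc1ccc2[nH]c(=O)c(/C=N/Nc3ccccc3)cc2c1`: 1470000 nM
Compound 3, `O=c1[nH]c2ccccc2cc1/C=N/Nc1ccccc1`: 1000000 nM

The three measured compounds were tested in a functional assay, read by spectrophotometry, with a stated time of 1 h; a lower number here means a stronger inhibitor, a higher number a weaker inhibitor. In this assay compound 1 gives 1350000 nM, compound 2 gives 1470000 nM and compound 3 gives 1000000 nM. All three numbers lie close together, and neither step between them leaves the usual scatter: a 1.1-fold higher number from compound 1 to compound 2 (0.04 log units; within the scatter), and a 1.5-fold lower number from compound 2 to compound 3 (0.17 log units; within the scatter).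

Compound 4, `O=c1[nH]c2ccccc2cc1/C=N/c1ccccc1O`, has not yet been measured. It differs from compound 1 in one place: hydrogen in place of methyl on an aromatic carbon. The same change, with the same surroundings, has already been made once among the measured compounds, from compound 2 to compound 3: hydrogen in place of methyl on an aromatic carbon, where the step in this assay was a 1.5-fold lower number from compound 2 to compound 3 (0.17 log units; within the scatter). The two cores on which the change is made are not identical; compound 1 differs from compound 2 as follows: 2-hydroxyphenyl in place of anilino on a double-bonded nitrogen.

Since that earlier step stayed within the scatter, compound 4 is expected to sit close to compound 1, with a step estimated as a 1.4-fold lower number from compound 1 to compound 4 (0.15 log units; within the scatter), resting on the measured step of a 1.5-fold lower number from compound 2 to compound 3 (0.17 log units; within the scatter). For compound 4 the value in this assay is therefore estimated at 950000 nM, expected to fall between 400000 nM and 2500000 nM.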

Compound 4, half-maximal inhibitory concentration: 1660000 nM
Beside the measured number, compound 4's estimate is 1.7-fold (0.24 log units) below it, and the stated range covers the measured number.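

In this assay hydrogen in place of methyl on an aromatic carbon gives a 1.2-fold higher number from compound 1 to compound 4 (0.09 log units; within the scatter) on the core of compound 1, so the step stays small on this core as well. Set beside the earlier case, the two steps cannot be told apart: the same change on two cores in this assay, a 1.5-fold lower number (0.17 log units; within the scatter) from compound 2 to compound 3 and a 1.2-fold higher number (0.09 log units; within the scatter) from compound 1 to compound 4, 1.8-fold (0.26 log units) apart, within the scatter of two such steps. This shows that, on these two cores, the change carries over without a measurable difference, but it does not show that the change has a real effect on either core, and it says nothing about how the change would behave on any other core.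

The compounds shown carry only methyl or hydrogen at this place on the ring, which leaves open what a longer chain such as ethyl, an ether such as methoxy, a halogen such as chlorine, or an amine or a carboxylic acid would do there. Also open, going by these compounds, is whether any of these groups would give a step in this assay that leaves the usual scatter, something neither of the two steps made with hydrogen in place of methyl has done.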